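Swapping the amide substituent on an inactive alkyne scaffold

This account rests on a few compounds, and the source may have more. Where it says the series, first, only, none or still open, it means among the compounds named here.

In a functional assay on HEK293 cells for negative allosteric modulation of metabotropic glutamate receptor 2 (Rattus norvegicus), read by calcium flux, with a stated time of 2.5 min (on this read-out higher numbers stand for weaker inhibition and lower numbers for stronger inhibition), the three measured compounds stand as follows, and each value is a limit of the assay rather than a number:

Compound 1, `COc1ccc(C#Cc2ccc(C(=O)N3CCCC(OC)C3)cc2)cc1`, gives > 30000 nM.
Compound 2, `COc1ccc(C#Cc2ccc(C(=O)N3CC4CCC(O)C4C3)cc2)cc1`, gives > 30000 nM.
Compound 3, `COc1ccc(C#Cc2ccc(C(=O)NC(C)CO)cc2)cc1`, gives > 30000 nM.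

Compound 3 therefore stands at the limit of > 30000 nM in this assay, at which 3 of the 3 values shown sit, and since compounds 1 and 2 sit at the same limit, no order among the three can be read. Compound 4, `COc1ccc(C#Cc2ccc(C(=O)N3CCCC(C)(O)C3)cc2)cc1`, differs from compound 3 in one place: 3-hydroxy-3-methylpiperidin-1-yl in place of (1-(hydroxymethyl)ethyl)amino on a carbonyl carbon. For the measured compounds named here, two measured steps touch the same carbonyl position. The step that the two limits leave unreadable from compound 1 to compound 3 exchanges a methoxy-bearing piperidine for the open-chain amino group, and the step that the two limits leave unreadable from compound 2 to compound 3 exchanges the fused bicyclic group for it; both are unreadable in size because their two ends sit at the limit of > 30000 nM in this assay, at which 3 of the 3 values shown sit. Going by the values given here, no step with a readable size is available, so neither a direction nor a magnitude can be drawn from the data for the change into compound 4. The expected step is accordingly a number no higher from compound 3 to compound 4 (the limit leaves the size open), meaning no change beyond the scatter. Compound 4 is thus estimated at 30000 nM, within a range from 10000 nM to 100000 nM, and is expected most likely to be reported once more only as a limit.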

Compound 4, half-maximal inhibitory concentration: > 30000 nM
Compound 4: only a limit was reported; the forecaster's own chance of this, stated with the estimate: 85%; the middle value lies on the limit itself.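

Compound 4 gives > 30000 nM, which is again a limit and not a number. The steps from compound 1, compound 2 and compound 3 to compound 4 therefore cannot be read, because all four compounds share the same limit: the limit of > 30000 nM in this assay, at which 4 of the 4 values shown sit.

The compounds shown leave open how the four rank and which amide substituent on the shared core, if any, would give an actual number.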